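The compounds below may be only part of what the source reports. "The series", "measured", "known", "first", "only" and "open" are said of these compounds alone.

Compound 3 `O=C(N1CCCCCC1)N1CC(c2nc(-c3cccc(Cl)c3)no2)C1` is measured in an assay on HEK293 cells for negative allosteric modulation of metabotropic glutamate receptor 5 (Homo sapiens), read by FLIPR; on this read-out lower numbers stand for stronger inhibition and higher numbers for weaker inhibition. For compound 3 this assay reports only a limit, > 10000 nM. Two close relatives share its core. Compound 1 `CC1CCCC(C(=O)N2CC(c3nc(-c4cccc(Cl)c4)no3)C2)C1` likewise gives only a limit in this assay, > 10000 nM. Compound 2 `O=C(N1CCC(F)CC1)N1CC(c2nc(-c3cccc(Cl)c3)no2)C1` also yields only a limit in this assay, > 10000 nM. The steps among them, a step that the two limits leave unreadable from compound 1 to compound 2, a step that the two limits leave unreadable from compound 1 to compound 3 and a step that the two limits leave unreadable from compound 2 to compound 3, have no readable size because of the limit of > 10000 nM in this assay, at which 3 of the 3 values shown sit. Compound 4 `CC1CCN(C(=O)N2CC(c3nc(-c4cccc(Cl)c4)no3)C2)CC1` has not yet been measured. It differs from compound 3 by 4-methylpiperidin-1-yl in place of azepan-1-yl on a carbonyl carbon. Among the measured compounds shown here, all three measured neighbours sit at the limit, and none of the measured steps therefore gives a readable size for this change. For the measured compounds named here, nothing among the measured compounds points to a gain in potency on rearranging the amine. The study therefore expects no step beyond the scatter, a step that the limit leaves unreadable from compound 3 to compound 4. Compound 4 is expected to come out at the limit again, estimated at 15000 nM, within a range from 4000 nM to 60000 nM.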

Compound 4, half-maximal inhibitory concentration: > 10000 nM
Compound 4: a limit, no number (the forecaster's own chance of this, stated with the estimate: 85%); the middle value does not contradict the limit.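

In this assay, among the compounds shown here, no step from compound 1, compound 2 or compound 3 to compound 4 can be read, because compound 4 also gives only a limit: the limit of > 10000 nM in this assay, at which 4 of the 4 values shown sit. The compounds shown leave open which change to the shared core, if any, would give measurable inhibition.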